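Working notes: phenyl in place of cyclohexyl

A few compounds are considered here, and "the series" means these few. Any claim that something is new, unique, unknown or untested is made for them only; others in the source may bear on it.

Values measured in a functional assay (ileum) for inhibition, with Cavia porcellus as the target (on this read-out higher numbers stand for weaker inhibition and lower numbers for stronger inhibition), are:
- compound 1 `Oc1nc(NCC2CCCCC2)nc2ccc(Cl)cc12` gives 23900 nM
- compound 2 `C[C@@H](Nc1nc(O)c2cc(Cl)ccc2n1)C1CCCCC1` gives 8200 nM
- compound 3 `C[C@H](Nc1nc(O)c2cc(Cl)ccc2n1)C1CCCCC1` gives 15100 nM

Compound 2 has the lowest number of the three, clear of one neighbour (a 2.9-fold lower number from compound 1 to compound 2 (0.46 log units; beyond the scatter)) but not of the other (a 1.8-fold higher number from compound 2 to compound 3 (0.27 log units; within the scatter)). Compound 4 `C[C@@H](Nc1nc(O)c2cc(Cl)ccc2n1)c1ccccc1` carries phenyl in place of cyclohexyl (phenyl in place of cyclohexyl on a saturated chain carbon bound to a nitrogen on an aromatic ring and a saturated chain carbon) on a saturated chain carbon bound to a nitrogen on an aromatic ring and a saturated chain carbon. Within the data shown here, no measured step changes this ring, so the guides are indirect: the methyl steps (a 2.9-fold lower number from compound 1 to compound 2 (0.46 log units; beyond the scatter) and a 1.6-fold lower number from compound 1 to compound 3 (0.20 log units; within the scatter)) and the configuration step above are all small. In this assay the expected step (a 1.2-fold higher number from compound 2 to compound 4 (0.09 log units; within the scatter)) stays within the scatter. Estimated value for compound 4: 10000 nM (expected range 3500 nM to 30000 nM).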

Compound 4, half-maximal inhibitory concentration: 20200 nM
Beside the measured number, compound 4's estimate is 2.0-fold (0.31 log units) below it; the range from low to high includes it.
By their numbers in this assay, from the lowest: compounds 2, 3, 4 and 1 (each within the scatter of the next, the first and the last beyond it).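

Swapping cyclohexyl for phenyl at this position leaves the heavy atom count unchanged yet gives a 2.5-fold higher number from compound 2 to compound 4 (0.39 log units; beyond the scatter) in this assay, so in this pair the saturated ring gives the stronger inhibition. The ring on this saturated chain carbon therefore affects the read-out, though only modestly. Nothing available explains this step.

From the compounds shown here alone, it remains open how a pyridyl or cyclopentyl ring would read at this place. Going by these compounds, the opposite configuration of compound 4 is also open, as is whether any ring here can bring the number well below that of compound 2.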